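Swapping 2-methoxyphenyl for 4-fluorophenyl on the shared core

This account rests on a few compounds, and the source may have more. Where it says the series, first, only, none or still open, it means among the compounds named here.

Compound 1, `Cc1ccc(Nc2cc(C)nc(SCc3nc4ccccc4[nH]3)n2)cc1`, gives 56500 nM in a functional assay on MCF7 cells (Homo sapiens) for cytotoxicity, read by MTT assay, with a stated time of 72 h; a higher number here means a weaker inhibitor, a lower number a stronger inhibitor.
Compound 2, `Cc1cc(N2CCNCC2)nc(SCc2nc3ccccc3[nH]2)n1`, sits at the limit of > 100000 nM in this assay.
Compound 3, `COc1ccccc1Nc1cc(C)nc(SCc2nc3ccccc3[nH]2)n1`, also sits at the limit of > 100000 nM in this assay.

Compound 3 thus stands at a limit and not at a number, and its position relative to compound 1 is fixed only as a floor: an at least 1.7-fold higher number from compound 1 to compound 3 (0.24 log units; that floor lies within the scatter). Two of the three values sit at that limit (the limit of > 100000 nM in this assay, at which 2 of the 3 values shown sit), so the readable range is narrow.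

Compound 4, `Cc1cc(Nc2ccc(F)cc2)nc(SCc2nc3ccccc3[nH]2)n1`, differs from compound 3 in one place: 4-fluorophenyl in place of 2-methoxyphenyl on a nitrogen on an aromatic ring. The 4-fluorophenyl of compound 4 resembles the 4-methylphenyl of compound 1 more than the 2-methoxyphenyl of compound 3. Within the data shown here, the only step that bears on the change is the one from compound 1 to compound 3, whose floor lies within the scatter, so no step beyond the scatter is expected in this assay, with a chance that compound 4 falls back toward compound 1 or again reaches the limit. Compound 4 is therefore estimated at 80000 nM, with a range from 35000 nM to 200000 nM. The expected step is an at least 1.2-fold lower number from compound 3 to compound 4 (0.09 log units; that floor lies within the scatter).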

Compound 4, half-maximal inhibitory concentration: 42200 nM
Beside the measured number, compound 4's estimate is 1.9-fold (0.28 log units) above it; the range from low to high includes it.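

In this assay, the change on this nitrogen now gives a step that reads as beyond the scatter, an at least 2.3-fold lower number from compound 3 to compound 4 (0.37 log units; beyond the scatter), whereas the earlier floor for the 2-methoxyphenyl change stayed within it. A second such step appears on the aromatic carbon, where (4-fluorophenyl)amino takes the place of piperazin-1-yl, an at least 2.3-fold lower number from compound 2 to compound 4 (0.37 log units; beyond the scatter). Fluoro in place of methyl on the aromatic carbon gives only a 1.3-fold lower number from compound 1 to compound 4 (0.13 log units; within the scatter), so 4-fluorophenyl and 4-methylphenyl cannot be told apart here.

As far as these compounds go, the two new floors give no true size, and the step between compound 2 and compound 3 cannot be read, as both compounds stand at a limit: the limit of > 100000 nM in this assay, at which 2 of the 4 values shown sit. It remains open how 4-methoxyphenyl or 4-chlorophenyl on this nitrogen would read in this assay.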